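The compounds below may be only part of what the source reports. "The series", "measured", "known", "first", "only" and "open" are said of these compounds alone.

For the measured compounds named here, in a functional assay on B16-F10 cells (Mus musculus) for antiproliferative activity, read by MTT assay, with a stated time of 48 h (a lower number here means a stronger inhibitor, a higher number a weaker inhibitor), the compounds measured so far read as follows.

Compound 1 `CC(=O)N1N=C(c2ccc3ccccc3c2)OC1c1ccc(Cl)cc1` gives 2.48 ug/mL
Compound 2 `CC(=O)N1N=C(c2ccc3ccccc3c2)OC1c1ccccc1O` gives 2.58 ug/mL

Going by the values given here, compound 2 stands within the scatter of compound 1, the only other compound measured, so the two cannot be ranked. Compound 3 `CC(=O)N1N=C(c2ccc3ccccc3c2)OC1c1ccccn1` has pyridin-2-yl in place of 2-hydroxyphenyl on a saturated ring carbon. Among the compounds with values here, the one measured step at that carbon (a 1.0-fold higher number from compound 1 to compound 2 (0.02 log units; within the scatter)) put 2-hydroxyphenyl in place of 4-chlorophenyl and stayed within the scatter. Within the data shown here, no measured compound carries pyridin-2-yl, so that step is only a loose guide. Going by it, no shift beyond the scatter is expected in this assay in either direction, and the estimated move is small (a 1.1-fold higher number from compound 2 to compound 3 (0.04 log units; within the scatter)). The estimate for compound 3 is 2.8 ug/mL with an expected range of 1.2 ug/mL to 6.5 ug/mL in this read-out.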

Compound 3, half-maximal inhibitory concentration: 7.18 ug/mL
Estimate against measurement, compound 3: 2.6-fold (0.41 log units) below; measured number above the stated range.
By their numbers in this assay, from the lowest: compounds 1 and 2 (each within the scatter of the next); then compound 3.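

In this assay, the saturated ring carbon turns out not to be indifferent to the group it carries: pyridin-2-yl gives a higher number, and so a weaker inhibitor, than 2-hydroxyphenyl (a 2.8-fold higher number from compound 2 to compound 3 (0.44 log units; beyond the scatter)) and than 4-chlorophenyl (a 2.9-fold higher number from compound 1 to compound 3 (0.46 log units; beyond the scatter)). For the compounds shown here, the earlier step at this carbon stayed within the scatter, so these are the first changes here to go beyond it, though only modestly, and both replace an aromatic ring of carbon only with one holding a hetero atom. No measurement at hand accounts for this shift.

The compounds shown leave open whether the ring nitrogen itself or its place in the ring goes with the higher number, which pyridin-3-yl and pyridin-4-yl would test. They also do not show how unsubstituted phenyl would read at this carbon.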